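A Pyrimidinyl Replacement at the Ring Amine

The source may hold more compounds than are shown below. What is called first, only, known or untested is meant among the compounds shown, and "the series" means these compounds.

Of the compounds shown here, two sharing one core have been measured in an assay on Cerebral cortex for displacement of a labelled ligand from Adrenergic receptor alpha-1 (Rattus norvegicus); a lower number here means a stronger inhibitor, a higher number a weaker inhibitor. Compound 1 `Cc1ccc(-c2nn(CCN3CCN(c4ccccc4)CC3)c(=O)c3ccccc23)cc1` gives 25.3 nM. Compound 2 `Cc1ccc(-c2nn(CCCCN3CCN(c4ccccc4OC(C)C)CC3)c(=O)c3ccccc23)cc1` gives 1.07 nM, the lowest of the two numbers, and the gap to compound 1 lies well beyond the scatter of repeated measurements. Among the compounds with values here, since compound 1 and compound 2 differ in more than one place, no single step between measured compounds can be drawn from them.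

Compound 3 `Cc1ccc(-c2nn(CCCCN3CCN(c4ncccn4)CC3)c(=O)c3ccccc23)cc1` is the next member and differs from compound 2 by pyrimidin-2-yl in place of 2-isopropoxyphenyl on an amine nitrogen in a ring. With only the change itself to go on, the author expects this exchange to weaken binding, so that the step from compound 2 to compound 3 should raise the number beyond the scatter, estimated as a 19-fold higher number from compound 2 to compound 3 (1.27 log units; beyond the scatter). For compound 3 in this assay the estimated inhibition constant is 20 nM, with a plausible range from 4 nM to 100 nM.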

Compound 3, inhibition constant: 270 nM
Compound 3: the middle estimate sits 14-fold (1.13 log units) below what was measured; the whole stated range lies below it.
By their numbers in this assay, from the lowest: compound 2; then compound 1; then compound 3.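

Within the data shown here, the step gives the first reading of a single change at this position, which compound 1 and compound 2 could not provide because they differ in more than one place. In this assay, pyrimidin-2-yl in place of 2-isopropoxyphenyl on the amine nitrogen in the ring brings a 250-fold higher number from compound 2 to compound 3 (2.40 log units; beyond the scatter), so with the rest of the structure held fixed, this position is far from indifferent to the group it carries. Nothing available explains the size of this loss.

Since the change replaces both the ring and its isopropoxy group, the compounds shown leave open whether the loss follows the ring nitrogens or the missing isopropoxy group. An unsubstituted phenyl or a 2-methoxyphenyl group on the chain of compound 2 would help separate the two.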